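This account rests on a few compounds, and the source may have more. Where it says the series, first, only, none or still open, it means among the compounds named here.

Among the measured compounds shown here, in a functional assay on SMMC-7721 cells (Homo sapiens) for antiproliferative activity, read by MTT assay, with a stated time of 72 h (a lower number here means a stronger inhibitor, a higher number a weaker inhibitor), compound 3 `CN(c1ccc2[nH]c(-c3n[nH]c4ccccc34)cc2n1)S(=O)(=O)c1ccc(Cl)cc1` gives 12700 nM, the lowest of the three numbers so far. Compound 2 `CN(C(=O)C(C)(C)C)c1ccc2[nH]c(-c3n[nH]c4ccccc34)cc2n1` gives 22200 nM in this assay, and compound 1 `CCC(=O)N(C)c1ccc2[nH]c(-c3n[nH]c4ccccc34)cc2n1` gives 33500 nM. Compound 4 `COc1ccc(S(=O)(=O)N(C)c2ccc3[nH]c(-c4n[nH]c5ccccc45)cc3n2)cc1OC` differs from compound 3 in a single place: 3,4-dimethoxyphenyl in place of 4-chlorophenyl on a sulfonyl sulfur. The measured steps do not touch that ring. The step of a 2.6-fold lower number from compound 1 to compound 3 (0.42 log units; beyond the scatter) and the step of a 1.7-fold lower number from compound 2 to compound 3 (0.24 log units; within the scatter) both replace an acyl group on the nitrogen with the (4-chlorophenyl)sulfonyl group, and the step of a 1.5-fold lower number from compound 1 to compound 2 (0.18 log units; within the scatter) changes only the acyl group; none of them alters the aryl ring on the sulfonyl sulfur. For the measured compounds named here, with no measured step bearing directly on the change, the expectation in this assay is a step of no more than modest size, with no clear direction, most likely within the scatter, so the value of compound 4 is expected to lie close to that of compound 3, written as a 1.1-fold lower number from compound 3 to compound 4 (0.02 log units; within the scatter). Compound 4 is therefore estimated at 12000 nM, with a range from 5000 nM to 30000 nM.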

Compound 4, half-maximal inhibitory concentration: 26600 nM
Compound 4: the middle estimate sits 2.2-fold (0.35 log units) below what was measured, and the stated range covers the measured number.
By their numbers in this assay, from the lowest: compounds 3, 2, 4 and 1 (each within the scatter of the next, the first and the last beyond it).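

In this assay, the aryl ring on the sulfonyl sulfur proves able to shift the number: with 3,4-dimethoxyphenyl in place of 4-chlorophenyl, the result is a 2.1-fold higher number from compound 3 to compound 4 (0.32 log units; beyond the scatter), a modest step toward a weaker inhibitor. Among the compounds shown here, the earlier steps only exchanged one acyl group for another or an acyl group for the (4-chlorophenyl)sulfonyl group, so this is the first reading of any change on that ring. Nothing measured here explains the step.

With only this one pair, the compounds shown cannot separate the loss of the chlorine from the arrival of the two methoxy groups. On these data alone, it remains open how a plain phenyl, or a ring carrying an amine or a carboxylic acid, would read on the same sulfonyl sulfur.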